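The compounds below may be only part of what the source reports. "The series", "measured", "known", "first", "only" and "open" are said of these compounds alone.

Going by the values given here, in an ADME assay for permeability, using PAMPA, with a stated time of 4 h, at pH 7.4 (a higher number here means that the compound crosses the layer faster, a lower number that the compound crosses the layer more slowly), three compounds have numbers so far. Compound 1 (`NCCCCN(C[C@@H]1Cc2nccnc2CN1)[C@H]1CCCc2cccnc21`) gives 2 nm/s and compound 2 (`CN(C[C@@H]1Cc2ncccc2CN1)[C@H]1CCCc2cccnc21`) gives 1000 nm/s while compound 3 (`NC/C=C/CN(C[C@H]1Cc2ncccc2CN1)[C@H]1CCCc2cccnc21`) gives 15 nm/s and so stands in the middle, with gaps beyond the scatter on both sides. Compound 4 (`CN(C)CCCCN(C[C@H]1Cc2ncccc2CN1)[C@H]1CCCc2cccnc21`) carries 3-(dimethylamino)propyl in place of 3-aminoprop-1-en-1-yl on a saturated chain carbon bound to an amine nitrogen. Among the compounds with values here, no measured pair shows this kind of change, so the size is uncertain. A moderate rise in this assay is expected, still well short of the number for compound 2, which stands at 1000 nm/s on that scale. The step expected is a 2.7-fold higher number from compound 3 to compound 4 (0.43 log units; beyond the scatter) and it remains an estimate. For compound 4 the estimated value is 40 nm/s with an expected range from 10 nm/s to 150 nm/s in this assay.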

Compound 4, apparent permeability: 240 nm/s
Compound 4: the middle estimate sits 6.0-fold (0.78 log units) below what was measured; the whole stated range lies below it.
By their numbers in this assay, from the lowest: compound 1; then compound 3; then compound 4; then compound 2.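

On a saturated chain carbon bound to an amine nitrogen, 3-(dimethylamino)propyl in place of 3-aminoprop-1-en-1-yl gives a 16-fold higher number from compound 3 to compound 4 (1.20 log units; beyond the scatter) in this assay, so this position can shift the read-out strongly. The swap changes several things at once: the entering group has more heavy atoms, no double bond outside aromatic rings and 0 hydrogen-bond donors, where the leaving group has 1. Nothing available explains the step. On these data alone, how much of it follows the double bond and how much the methyl groups on the nitrogen stays open, as does the outcome with a methylamino group ending the saturated chain.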